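Replacing the ring on the side chain with carbamoylmethyl

A few compounds are considered here, and "the series" means these few. Any claim that something is new, unique, unknown or untested is made for them only; others in the source may bear on it.

Measured compounds:
- Compound 1 `CC(C)C(c1ccc(-c2ccc3cccc(F)c3c2)[nH]c1=O)N1CCCCS1(=O)=O`: 122 nM
- Compound 2 `CC(C)C(Cc1nnn[nH]1)c1ccc(-c2ccc3cccc(F)c3c2)[nH]c1=O`: 134 nM
- Compound 3 `CC(C)C(c1ccc(-c2ccc3cccc(F)c3c2)[nH]c1=O)N1CCNC1=O`: 28 nM

All three compounds share the same core and differ only in the group attached to the saturated chain carbon bound to an aromatic carbon and a saturated chain carbon. In a functional assay on CHO cells for antagonist activity at prostaglandin E2 receptor EP3 subtype (Homo sapiens), read by cAMP accumulation (a higher number here means a weaker inhibitor, a lower number a stronger inhibitor), compound 1 gives 122 nM, the second highest of the three numbers; it sits close to compound 2 and well apart from compound 3. Compound 4 `CC(C)C(CC(N)=O)c1ccc(-c2ccc3cccc(F)c3c2)[nH]c1=O` is the next compound, and it differs from compound 1 as follows: a group of 4 heavy atoms (2 carbon, 1 nitrogen, 1 oxygen; no ring) in place of a group of 8 heavy atoms (4 carbon, 1 nitrogen, 2 oxygen, 1 sulfur; one six-membered non-aromatic ring with 2 hetero atoms), on a saturated chain carbon bound to an aromatic carbon and a saturated chain carbon. The group that enters has no ring and one hydrogen-bond donor, unlike the group that leaves.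

Two measured steps start from compound 1 and speak to this change. The swap to an aromatic ring bearing no donor gave a 1.1-fold higher number from compound 1 to compound 2 (0.04 log units; within the scatter), while the swap to a non-aromatic ring with a donor gave a 4.4-fold lower number from compound 1 to compound 3 (0.64 log units; beyond the scatter). Carbamoylmethyl brings a donor but no ring, so it sits between those two cases, and no step beyond the scatter is firmly expected in this assay. Compound 4 is therefore estimated at 130 nM, with a range of 35 nM to 500 nM, which would mean a 1.1-fold higher number from compound 1 to compound 4 (0.03 log units; within the scatter).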

Compound 4, half-maximal inhibitory concentration: 53 nM
Compound 4: middle estimate off by 2.5-fold (0.39 log units), on the high side, and the stated range covers the measured number.
By their numbers in this assay, from the lowest: compounds 3 and 4 (each within the scatter of the next); then compounds 1 and 2 (each within the scatter of the next).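

In this assay the swap to carbamoylmethyl gives a 2.3-fold lower number from compound 1 to compound 4 (0.36 log units; beyond the scatter) and so shows that a group with no ring, and with fewer heavy atoms than the six-membered ring of compound 1, can give a stronger inhibitor at this saturated chain carbon. The open group also stands level with the ring of compound 3: carbamoylmethyl in place of 2-oxoimidazolidin-1-yl gives a 1.9-fold higher number from compound 3 to compound 4 (0.28 log units; within the scatter) and leaves the two groups unresolved in this assay even though only one of them has a ring. Compounds 2 and 4 keep the same chain and differ only in the group at its end, and this change gives a 2.5-fold lower number from compound 2 to compound 4 (0.40 log units; beyond the scatter) as the first sign that the end group alone can move the number.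

A carboxylic acid in place of the carbamoyl, or a longer chain ending in the same carbamoyl, would show how much of this result depends on the exact group and its distance from the shared core. The same question stands for an amine at the end of the chain. Nothing measured here gives a reason for these differences.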